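Piperidine methyl placement and lipophilicity in the series

A few compounds are considered here, and "the series" means these few. Any claim that something is new, unique, unknown or untested is made for them only; others in the source may bear on it.

Compound 1 `CC(C)Sc1nnc(-c2c(CNCC3CC3)c3cc(F)ccc3n2C)n1-c1ccccc1` gives 5.4 in a physicochemical assay for lipophilicity; a higher number here means a more lipophilic compound, a lower number a more polar compound. Compound 2 `CC(C)Sc1nnc(-c2c(CNCCN3CCCC3)c3cc(F)ccc3n2C)n1-c1ccccc1` gives 4.99 in this assay, and compound 3 `CC1CCCN(Cc2c(-c3nnc(SC(C)C)n3-c3ccccc3)n(C)c3ccc(F)cc23)C1` gives 6.18 in this assay. Compound 3 stands highest of the three measured numbers: a number 0.78 log units higher from compound 1 to compound 3 (beyond the scatter), and a number 1.19 log units higher from compound 2 to compound 3 (beyond the scatter). The third measured step runs the other way: a number 0.41 log units lower from compound 1 to compound 2 (beyond the scatter).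

Compound 4 `CC1CCN(Cc2c(-c3nnc(SC(C)C)n3-c3ccccc3)n(C)c3ccc(F)cc23)CC1` differs from compound 3 in one place only: 4-methylpiperidin-1-yl in place of 3-methylpiperidin-1-yl on a saturated chain carbon bound to an aromatic carbon. For the measured compounds named here, none of the measured steps bears directly on this change. Each of them exchanges one amine-bearing group for another of different build, with a different count of atoms or a ring in place of a chain, and those exchanges produced the modest and large shifts noted above. Going by the values given here, the step from compound 3 to compound 4 keeps the same atoms and the same ring, joined differently, so nothing among the measured compounds points to a shift in either direction.

In this assay the step from compound 3 to compound 4 is therefore expected to be none beyond the scatter, a number 0.02 log units higher from compound 3 to compound 4 (within the scatter). Compound 4 is estimated to give 6.2 in this assay, with a range from 5.85 to 6.55.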

Compound 4, partition coefficient: 6.12
Compound 4: middle estimate off by 0.08 log units, on the high side; low and high end bracket the measured number.
By their numbers in this assay, from the lowest: compound 2; then compound 1; then compounds 4 and 3 (each within the scatter of the next).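

For the compounds shown here, with 4-methylpiperidin-1-yl in place of 3-methylpiperidin-1-yl on a saturated chain carbon bound to an aromatic carbon, this assay gives the first reading of a change that keeps the same atoms and the same ring and only joins them differently (a number 0.06 log units lower from compound 3 to compound 4 (within the scatter)). The two methylpiperidine compounds therefore read alike in this series, and the large and modest gaps seen for compound 3 against the two secondary amines recur for compound 4 (a number 1.13 log units higher from compound 2 to compound 4 (beyond the scatter); a number 0.72 log units higher from compound 1 to compound 4 (beyond the scatter)). No measurement in hand accounts for the near-identity of the two methylpiperidines or for the size of these steps.

The compounds shown leave open what the methyl itself contributes: plain piperidin-1-yl would separate the methyl from the ring, and the present pair only tells that moving it between these two places on the ring makes no reading beyond the scatter. Also open, on these data alone, is whether the same insensitivity holds once the methyl gives way to a hydroxyl or a carboxylic acid on the piperidine ring, or once morpholine replaces that ring.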